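Adding a Fluorine to the Anilide Ring of Compound 3

This account rests on a few compounds, and the source may have more. Where it says the series, first, only, none or still open, it means among the compounds named here.

Measured so far:
- compound 1, `O=C(Nc1ccc(-c2cscn2)cc1)C1CCCN(Cc2cccc(F)c2)C1`, 5000 nM
- compound 2, `O=C(Nc1ccc(-c2cscn2)cc1)C1CCCN(Cc2cccc(F)c2F)C1`, 10000 nM
- compound 3, `O=C(Nc1ccc(-c2ccc[nH]2)cc1)[C@H]1CCCN(Cc2ccc(F)c(F)c2)C1`, 140 nM

All three compounds were tested in a functional assay on A-375 cells (Homo sapiens) for activation, with a stated time of 3 days; on this read-out higher numbers stand for an effect only at larger amounts of compound and lower numbers for an effect already at smaller amounts. Compound 1 and compound 2 share one core; compound 3 has a different core, and the difference between the two cores is not broken down here. In this assay compound 3 gives the lowest of the three numbers, and its step to compound 1 and to compound 2 is in each case beyond the scatter.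

Among the compounds with values here, the one step that is measured between compounds differing in a single place is a 2.0-fold higher number from compound 1 to compound 2 (0.30 log units; within the scatter). The change is fluoro in place of hydrogen on an aromatic carbon.

Compound 4, `O=C(Nc1ccc(-c2ccc[nH]2)cc1F)[C@H]1CCCN(Cc2ccc(F)c(F)c2)C1`, is not yet measured. It differs from compound 3 by fluoro in place of hydrogen on an aromatic carbon. Within the data shown here, this is the same kind of change as the one from compound 1 to compound 2, but not the same: in compound 2 the new fluoro sits ortho to a fluoro group (1 heavy atom) and ortho to a large group, whereas in compound 4 it sits ortho to a large group and meta to a 1H-pyrrol-2-yl group (5 heavy atoms), on a different ring of the molecule.

Among the measured compounds shown here, for compound 4 in this assay a step of a 1.4-fold higher number from compound 3 to compound 4 (0.15 log units; within the scatter) is expected, because the only comparable step, a 2.0-fold higher number from compound 1 to compound 2 (0.30 log units; within the scatter), stayed within the scatter. Compound 4 is therefore estimated at 200 nM, with a likely range from 60 nM to 700 nM.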

Compound 4, half-maximal effective concentration: 100 nM
For compound 4 the middle estimate is 2.0-fold (0.30 log units) above the measured one; the measured number falls inside the stated range.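

In this assay, the new step is a 1.4-fold lower number from compound 3 to compound 4 (0.15 log units; within the scatter), so on the core of compound 3 this fluoro leaves the number unchanged as far as repeated measurements can tell. Set beside the earlier case, the same kind of change does not carry over as one fixed step from one core to the other: the same change on two cores in this assay, a 2.0-fold higher number (0.30 log units; within the scatter) from compound 1 to compound 2 and a 1.4-fold lower number (0.15 log units; within the scatter) from compound 3 to compound 4, 2.8-fold (0.45 log units) apart, beyond the scatter of two such steps. This does not show that the core alone sets that gap, for the new fluoro also stands in a different place in compound 2 and in compound 4, each step on its own stays within the scatter, and two steps are a thin basis for any rule about the series.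

The compounds shown leave open whether a fluoro placed as in compound 4 would give a similar step on the core of compound 1, which would separate the effect of the core from that of the place. They also leave open whether another group on that same aromatic carbon, such as a chlorine, a methoxy group or an amine, would move the number beyond the scatter.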